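Clearance of a secondary versus tertiary amide analogue

This account rests on a few compounds, and the source may have more. Where it says the series, first, only, none or still open, it means among the compounds named here.

Measured so far:
compound 1, `CC(C)NC(=O)[C@H]1CC[C@@H](n2/c(=N/C(=O)c3ccc(F)c(F)c3)[nH]c3ccc(CN4CCC(C(C)(C)O)CC4)cc32)CC1`, 60 mL.min-1.g-1
compound 2, `CC(C)NC(=O)[C@H]1CC[C@@H](n2/c(=N/C(=O)c3ccc(C#N)c(F)c3)[nH]c3ccc(CN4CCC(C(C)(C)O)CC4)cc32)CC1`, 132 mL.min-1.g-1
compound 3, `CCN(CC)C(=O)[C@H]1CC[C@@H](n2/c(=N/C(=O)c3ccccc3)[nH]c3ccc(CN4CCCCC4)cc32)CC1`, 364 mL.min-1.g-1

These three compounds were tested in an in vitro ADME assay on microsomes from liver (Homo sapiens) for metabolic stability; a higher number here means faster removal of the compound, a lower number slower removal. Among them compound 3 gives the highest number, with compound 2 its nearest neighbour and compound 1 the furthest away, both gaps beyond the scatter. Within the data shown here, the one single-point step recorded, a 2.2-fold higher number from compound 1 to compound 2 (0.34 log units; beyond the scatter), concerns an aromatic substituent and does not touch the amide.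

Compound 4, `CC(C)NC(=O)[C@H]1CC[C@@H](n2/c(=N/C(=O)c3ccccc3)[nH]c3ccc(CN4CCCCC4)cc32)CC1`, differs from compound 3 in one place: isopropylamino in place of diethylamino on a carbonyl carbon. Among the measured compounds shown here, no measured pair isolates this change. Compound 1 and compound 2 both carry the isopropylamino amide and show lower numbers than compound 3, but they also differ from it in two other places, so their values only hint at the direction. For compound 4 a modest drop is therefore expected, a 1.5-fold lower number from compound 3 to compound 4 (0.18 log units; within the scatter), with wide uncertainty. The estimate for compound 4 in this assay is 240 mL.min-1.g-1, expected to lie between 110 mL.min-1.g-1 and 500 mL.min-1.g-1.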

Compound 4, intrinsic clearance in microsomes: 203 mL.min-1.g-1
The estimate for compound 4 lay 1.2-fold (0.07 log units) above the measured number, within the range that was stated.
By their numbers in this assay, from the lowest: compound 1; then compounds 2, 4 and 3 (each within the scatter of the next, the first and the last beyond it).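

Among these compounds, the amide is the only thing that differs between this pair, so it gives the first direct reading of this change on a carbonyl carbon whose other neighbour is a saturated ring carbon. In this assay the step is a 1.8-fold lower number from compound 3 to compound 4 (0.25 log units; within the scatter) and stays within the scatter, so on this background the two amides cannot be told apart, even though diethylcarbamoyl has no hydrogen-bond donor and isopropylcarbamoyl has one. Nothing available here gives a reason for this result.

It remains open whether the same swap would read alike on compound 1 or compound 2, whose diethylamino partners are not among the compounds shown. Other groups in this place, such as methylamino or a pyrrolidine ring, also remain open, and either might move the number beyond the scatter.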